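Methyl at the benzamide ring: compound 4 versus compound 1

The source may hold more compounds than are shown below. What is called first, only, known or untested is meant among the compounds shown, and "the series" means these compounds.

Measured so far in an ADME assay on J774 cells (Mus musculus, strain BALB/c) for cytotoxicity, read by resazurin assay, with a stated time of 72 h; a higher number here means that more compound is tolerated, a lower number that less compound is tolerated:
- compound 1 `CC(/C=N/Nc1ccc([N+](=O)[O-])cc1)=N\NC(=O)c1ccccc1`: > 100000 nM, a limit of the assay.
- compound 2 `CC(/C=N/Nc1ccc([N+](=O)[O-])cc1)=N\NC(=O)c1ccccc1F`: > 100000 nM, also a limit.
- compound 3 `CC(/C=N/Nc1ccc([N+](=O)[O-])cc1)=N\NC(=O)c1ccccc1N`: 29800 nM.

Compound 1 stands at the limit; it shares that with compound 2 (the limit of > 100000 nM in this assay, at which 2 of the 3 values shown sit). Compound 4 `CC(/C=N/Nc1ccc([N+](=O)[O-])cc1)=N\NC(=O)c1cccc(C)c1` differs from compound 1 by methyl in place of hydrogen on an aromatic carbon. Of the measured steps, a step that the two limits leave unreadable from compound 1 to compound 2 stays unreadable between two limits, whereas an at least 3.3-fold lower number from compound 1 to compound 3 (0.52 log units; beyond the scatter) and an at least 3.3-fold lower number from compound 2 to compound 3 (0.52 log units; beyond the scatter) are clear. For the measured compounds named here, no measured step introduces a methyl, so the nearest guide is the fluoro step, which left the value at the limit. Compound 4 is therefore expected to give about 120000 nM (range 40000 nM to 300000 nM), i.e. an expected step that the limit leaves unreadable from compound 1 to compound 4, most likely again reported only as a limit.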

Compound 4, half-maximal cytotoxic concentration: > 100000 nM
Compound 4: no number, only a limit; the forecaster's own chance of this, stated with the estimate: 70%; the middle value is on the limit's open side.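

Compound 4 is a limit of the assay in this assay, and its steps from compound 1 and from compound 2 cannot be read: the limit of > 100000 nM in this assay, at which 3 of the 4 values shown sit.

A methyl meta to a large group thus brings no readable fall, the first such result for a carbon group in the series. There is an at least 3.3-fold higher number from compound 3 to compound 4 (0.52 log units; beyond the scatter), so compound 3, with its 2-aminophenyl, remains the only one of the four with a number.

Any order among compound 1, compound 2 and compound 4 stays open. Also open, as far as these compounds go, is whether an amine, a carboxylic acid or a longer chain in place of this methyl would bring a number like that of compound 3.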